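Difluorophenyl for dimethylphenyl on the aromatic nitrogen

This account rests on a few compounds, and the source may have more. Where it says the series, first, only, none or still open, it means among the compounds named here.

In a functional assay on PC-12 cells (Rattus norvegicus) for cytotoxicity, read by MTT assay, with stated times of 2 h and 24 h, tested at 1 uM (a higher number here means a stronger effect of the compound at the concentration tested, a lower number a weaker effect), compound 3 `Cc1cc(C)cc(-n2nc(-c3ccc(C(F)(F)F)cc3O)nc2-c2ccccc2O)c1` gives 76.9%, the highest of the three numbers, yet both others sit within the scatter of it: compound 1 `CC(C)(C)c1ccc(-n2nc(-c3ccc(C(F)(F)F)cc3O)nc2-c2ccccc2O)cc1` gives 67.3% and compound 2 `Oc1cc(C(F)(F)F)ccc1-c1nc(-c2ccccc2O)n(-c2cccc(F)c2)n1` gives 67.2%. The steps among them were a number 9.6 percentage points higher from compound 1 to compound 3 (within the scatter), a number 9.7 percentage points higher from compound 2 to compound 3 (within the scatter) and a number 0.1 percentage points lower from compound 1 to compound 2 (within the scatter). Compound 4 `Oc1cc(C(F)(F)F)ccc1-c1nc(-c2ccccc2O)n(-c2cc(F)cc(F)c2)n1` differs from compound 3 in one place: 3,5-difluorophenyl in place of 3,5-dimethylphenyl on an aromatic nitrogen. The step from compound 2 to compound 3, which also exchanged a fluorine-bearing phenyl for 3,5-dimethylphenyl, stayed within the scatter, so no step beyond the scatter is expected here. Compound 4 is therefore estimated at 70%, between 58% and 82%, an expected step of a number 6.9 percentage points lower from compound 3 to compound 4 (within the scatter).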

Compound 4, a percentage reported as activity, at one concentration (the size of the read-out at that concentration, not a potency): 75.5%
Beside the measured number, compound 4's estimate is 5.5 percentage points below it, and the stated range covers the measured number.
By their numbers in this assay, from the lowest: compounds 2, 1, 4 and 3 (each within the scatter of the next).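

The 3,5-difluorophenyl group on the aromatic nitrogen reads much like 3,5-dimethylphenyl in this assay, with a number 1.4 percentage points lower from compound 3 to compound 4 (within the scatter) at this position. Fluoro in place of hydrogen on an aromatic carbon gives a number 8.3 percentage points higher from compound 2 to compound 4 (within the scatter) and the exchange for 4-(tert-butyl)phenyl gives a number 8.2 percentage points higher from compound 1 to compound 4 (within the scatter), so all four phenyl groups at this position remain within the scatter of one another. Nothing available explains why these groups read alike. From the compounds shown here alone, whether a group on this nitrogen such as a carboxylic acid, an amine or a longer chain would move the number beyond the scatter remains open.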